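The source may hold more compounds than are shown below. What is called first, only, known or untested is meant among the compounds shown, and "the series" means these compounds.

For the measured compounds named here, compound 2 `CC1=CSC(O)(c2cccc([N+](=O)[O-])c2)c2noc(=O)n21` is the only member of the series with a number in a functional assay on A2780 cells (Homo sapiens) for antiproliferative activity, read by MTT assay, with a stated time of 3 days; a lower number here means a stronger inhibitor, a higher number a weaker inhibitor: compound 2 gives 159000 nM. Compound 1 `COc1ccc(C2(O)SC=C(C)n3c2noc3=O)cc1` sits at a limit of this assay, > 100000 nM. Compound 3 `CCCCCCCCCCCCCCCOC1(c2ccc(Cl)cc2)SC=C(C)n2c1noc2=O` likewise sits at a limit of this assay, > 100000 nM. Going by the values given here, the series thus rests largely on (the limit of > 100000 nM in this assay, at which 2 of the 3 values shown sit), and no measured step separates any two of its members. Compound 4 `CC1=CSC(O)(c2cccc(Cl)c2)c2noc(=O)n21` is not yet measured; it differs from compound 2 by chloro in place of nitro on an aromatic carbon. Among the compounds with values here, no measured pair covers this change. With everything shown weak or at a limit, the expected step is a 1.1-fold lower number from compound 2 to compound 4 (0.03 log units; within the scatter), none beyond the scatter. Compound 4 is expected at about 150000 nM, between 50000 nM and 400000 nM, with a fair chance that this assay reports only a limit.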

Compound 4, half-maximal inhibitory concentration: > 100000 nM
Compound 4: no number, only a limit; the forecaster's own chance of this, stated with the estimate: 55%; the middle value does not contradict the limit.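

No step can be read between compound 2 and compound 4: in this assay, compound 4 gives only a limit, > 100000 nM. The compounds shown leave open whether any single change in this series yields a readable difference in activity.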